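The source may report more compounds than this note shows. Statements on the series, on what has been measured and on what is new or still open speak of the compounds shown alone.

Compound 1 `O=C(CCCCC1CCSS1)NCc1cn(CCCOc2ccc3cc(-c4ccc(Br)cc4)c(=O)oc3c2)nn1` and compound 2 `O=C(CCCCC1CCSS1)NCc1cn(CCCOc2ccc3cc(-c4ccc(Cl)cc4)c(=O)oc3c2)nn1` share one core, while compound 3 `O=C(CCCCC1CCSS1)NCc1cn(CCCCOc2ccc3cc(-c4ccc(Br)cc4)c(=O)oc3c2)nn1` and compound 4 `O=C(CCCCC1CCSS1)NCc1cn(CCCCOc2ccc3cc(-c4ccc(Cl)cc4)c(=O)oc3c2)nn1` share another; how the two cores differ is not broken down here. In a functional assay on PC-12 cells (Rattus norvegicus) for cytotoxicity, read by MTT assay, with stated times of 3 h and 2 h, tested at 50 uM (a higher number here means a stronger effect of the compound at the concentration tested, a lower number a weaker effect), compound 1 gives 74.7%. Compound 2 gives 79.4% in this assay. The change from compound 1 to compound 2 is chloro in place of bromo on an aromatic carbon, and the step it made, a number 4.7 percentage points higher from compound 1 to compound 2 (within the scatter), is a small one that sits inside the usual scatter, so the two values cannot be ordered.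

Compound 3 gives 47.6% in this assay, the lowest of the three numbers, and its gaps to compound 1 and to compound 2 both lie beyond the scatter.

Compound 4 differs from compound 3 by chloro in place of bromo on an aromatic carbon, the same change that separates compound 1 from compound 2, at a place described in the same words, so it counts as the same change. From compound 3 to compound 4 a step of about a number 4.4 percentage points higher from compound 3 to compound 4 (within the scatter) is expected because the same change gave a number 4.7 percentage points higher from compound 1 to compound 2 (within the scatter), a step that itself stayed within the scatter, so any movement here is likely to be small. On that basis compound 4 is expected to give about 52% in this assay, with the likely range running from 40% to 64%.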

Compound 4, a percentage reported as activity, at one concentration (the size of the read-out at that concentration, not a potency): 74.9%
Beside the measured number, compound 4's estimate is 22.9 percentage points below it; the measured number lies above the stated range.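

In this assay, chloro in place of bromo on an aromatic carbon does not carry over from one core to the other as a step of fixed size: the same change on two cores in this assay, a number 4.7 percentage points higher (within the scatter) from compound 1 to compound 2 and a number 27.3 percentage points higher (beyond the scatter) from compound 3 to compound 4, 22.6 percentage points apart, beyond the scatter of two such steps

On the core of compound 3, the change brings a number 27.3 percentage points higher from compound 3 to compound 4 (beyond the scatter), whereas on the core of compound 1 the same change left two values that cannot be ordered, so a step read on one of these cores is a poor guide to the step on the other. Among these compounds, this rests on only two matched pairs, however, and it shows neither why the cores respond differently nor how the 4-bromophenyl to 4-chlorophenyl change would behave on any further core.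

The compounds shown carry only bromo or chloro at this place on the ring, so it remains open whether fluoro, methoxy or a plain phenyl ring would show the same dependence on the core. As far as these compounds go, it also remains open whether the step would hold on a core with a longer chain, and because each read-out comes from a single concentration, these numbers say nothing about potency.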